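The compounds below may be only part of what the source reports. "The series", "measured", "known", "first", "only" and "open" are said of these compounds alone.

Compound 1 `COc1ccc2[nH]c([S+]([O-])Cc3nccc(N4CCCCC4)c3Cl)nc2c1` and compound 2 `COc1ccc2[nH]c([S+]([O-])Cc3nccc(N4CCCC4)c3Cl)nc2c1` share a core and differ in one place: pyrrolidin-1-yl in place of piperidin-1-yl on an aromatic carbon. In an ADME assay for pharmacokinetics, at pH 7.4 (on this read-out higher numbers stand for a longer-lived compound and lower numbers for a shorter-lived compound), compound 1 gives 175 h, and compound 2 gives 36 h; the step is a 4.9-fold lower number from compound 1 to compound 2 (0.69 log units; beyond the scatter). Compound 3 `COc1ccc2[nH]c([S+]([O-])Cc3cc(N4CCCCC4)c(Br)cn3)nc2c1` carries a different core, and how its core differs from that of compound 1 is not broken down here. In this assay compound 3 gives 864 h, the highest of the three numbers. Compound 4 `COc1ccc2[nH]c([S+]([O-])Cc3cc(N4CCCC4)c(Br)cn3)nc2c1` is not yet measured and differs from compound 3 by pyrrolidin-1-yl in place of piperidin-1-yl on an aromatic carbon. This is the same kind of change as before, though here the place is ortho to a bromo group rather than a chloro group. Resting on the earlier step of a 4.9-fold lower number from compound 1 to compound 2 (0.69 log units; beyond the scatter), the change is expected to give a 4.8-fold lower number from compound 3 to compound 4 (0.68 log units; beyond the scatter). Compound 4 is therefore estimated at 180 h in this assay, likely between 70 h and 450 h.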

Compound 4, half-life in the ADME assay: 49 h
For compound 4 the middle estimate is 3.7-fold (0.57 log units) above the measured one; the measured number lies below the stated range.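

In the ADME assay the new step is an 18-fold lower number from compound 3 to compound 4 (1.25 log units; beyond the scatter), so the direction of the change carries over from the core of compound 1 to the core of compound 3, but its size does not: the same change on two cores in the ADME assay, a 4.9-fold lower number (0.69 log units; beyond the scatter) from compound 1 to compound 2 and an 18-fold lower number (1.25 log units; beyond the scatter) from compound 3 to compound 4, 3.6-fold (0.56 log units) apart, beyond the scatter of two such steps

In a physicochemical assay for acid dissociation, the same change also moves the number on the core of compound 3, where compound 3 gives 5.4 and compound 4 gives 6.92, yet this shift is seen on one pair alone, so it is not shown to explain the larger drop: the measured acid dissociation constant of compound 3, 5.4, and of compound 4, 6.92, a number 1.52 log units higher (beyond the scatter)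

The compounds shown leave open whether the bromo group or some other feature of the core sets the size of the drop. They also leave open how a morpholin-4-yl ring or an open-chain dimethylamino group in the same place would compare on either core.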